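The source may report more compounds than this note shows. Statements on the series, on what has been measured and on what is new or still open speak of the compounds shown alone.

Compound 1 `O=C(Nc1cccc(-n2cc(-c3ccncc3)c(-c3ccc(Cl)c(O)c3)n2)c1)Nc1cccc(C(F)(F)F)c1`: > 32500 nM (a limit)
Compound 2 `COc1cc(-c2nn(-c3cccc(NC(=O)Nc4ccc(Cl)c(Cl)c4)c3)cc2-c2ccncc2)ccc1Cl`: 3480 nM

Going by the values given here, in a functional assay on IGROV-1 cells (Homo sapiens) for inhibition, read by sulforhodamine B assay, with a stated time of 48 h (on this read-out lower numbers stand for stronger inhibition of growth and higher numbers for weaker inhibition of growth), compound 2 gives 3480 nM, the only plain number here. For compound 1 the result in this assay is a limit, > 32500 nM (the limit of > 32500 nM in this assay, at which 1 of the 2 values shown sits). Compound 3 `O=C(Nc1cccc(-n2cc(-c3ccncc3)c(-c3ccc(Cl)c(O)c3)n2)c1)Nc1ccc(Cl)c(Cl)c1` is not yet measured; it comes from compound 2 by hydrogen in place of methyl on an oxygen on an aromatic ring. No step between measured compounds is shown. Compound 1 also carries the hydroxy and sits at its limit. In this assay compound 3 is therefore expected near 10000 nM, within 3000 nM to 35000 nM. This corresponds to an expected step of a 2.9-fold higher number from compound 2 to compound 3 (0.46 log units; beyond the scatter) towards weaker growth inhibition, beyond the usual scatter.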

Compound 3, concentration for total growth inhibition: > 32500 nM
Compound 3: only a limit was reported; the forecaster's own chance of this, stated with the estimate: 35%; at least 3.2-fold (0.51 log units) between middle value and limit.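

In this assay, going by these compounds alone, going from methoxy to hydroxy gives an at least 9.3-fold higher number from compound 2 to compound 3 (0.97 log units; beyond the scatter), the first readable step at this position, and it runs towards weaker growth inhibition. Compound 1 and compound 3 carry different groups on the amide-type nitrogen, yet the step between them cannot be read, because both stand at the same limit: the limit of > 32500 nM in this assay, at which 2 of the 3 values shown sit.

Where compound 3 truly lies beyond its limit stays open, so the full size of the loss is unknown. Also open, from the compounds shown here alone, is how an ethoxy group or an amine would behave in place of the methoxy.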